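Nitro removal on the phenyl ring of compound 3

The source may hold more compounds than are shown below. What is called first, only, known or untested is meant among the compounds shown, and "the series" means these compounds.

Compound 3 `N/C(=N/NC(CC(=O)c1ccc(-n2ccnc2)cc1)c1ccc([N+](=O)[O-])cc1)c1ccccn1` gives the lowest number of the three in an ADME assay on Vero cells (Chlorocebus sabaeus) for cytotoxicity, read by MTT assay, with a stated time of 72 h (on this read-out higher numbers stand for lower toxicity in this test and lower numbers for higher toxicity in this test), at 23100 nM, though compound 2 `N/C(=N/NC(CC(=O)c1ccc(-n2ccnc2)cc1)c1cccc([N+](=O)[O-])c1)c1ccccn1`, at 28700 nM, lies within the scatter of it. Compound 1 `N/C(=N/NC(CC(=O)c1ccc(-n2ccnc2)cc1)c1ccccc1[N+](=O)[O-])c1ccccn1` gives 48000 nM. The steps read a 2.1-fold lower number from compound 1 to compound 3 (0.32 log units; beyond the scatter) and a 1.2-fold lower number from compound 2 to compound 3 (0.09 log units; within the scatter), so only the move away from 2-nitrophenyl passes the scatter. Compound 4 `N/C(=N/NC(CC(=O)c1ccc(-n2ccnc2)cc1)c1ccccc1)c1ccccn1` differs from compound 3 by hydrogen in place of nitro on an aromatic carbon. For the measured compounds named here, no measured step removes the nitro group; the steps in hand only shift it, and a 1.7-fold lower number from compound 1 to compound 2 (0.22 log units; within the scatter) is likewise small. The change to compound 4 is therefore expected to give no step beyond the scatter, a 1.1-fold higher number from compound 3 to compound 4 (0.03 log units; within the scatter). Compound 4 is estimated at 25000 nM in this assay, with a range of 11000 nM to 55000 nM.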

Compound 4, half-maximal cytotoxic concentration: 63500 nM
For compound 4 the middle estimate is 2.5-fold (0.40 log units) below the measured one; the whole stated range lies below it.
By their numbers in this assay, from the lowest: compounds 3, 2, 1 and 4 (each within the scatter of the next, the first and the last beyond it).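

In this assay, for the compounds shown here, the earlier steps only shifted the nitro group, while hydrogen in place of nitro gives a 2.7-fold higher number from compound 3 to compound 4 (0.44 log units; beyond the scatter) and a 2.2-fold higher number from compound 2 to compound 4 (0.34 log units; beyond the scatter) and so passes the scatter from 4-nitrophenyl and 3-nitrophenyl. From 2-nitrophenyl the same change gives a 1.3-fold higher number from compound 1 to compound 4 (0.12 log units; within the scatter) so among these compounds the size of the step depends on where the nitro group stood. No evidence on the cause of this difference is available.

Open, as far as these compounds go, is whether the step belongs to nitro specifically or to any group on that aromatic carbon. An amine or a carboxylic acid in the same place would separate these two readings.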